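This account rests on a few compounds, and the source may have more. Where it says the series, first, only, none or still open, it means among the compounds named here.

In a functional assay on A549 cells (Homo sapiens) for cytotoxicity, read by MTT assay, with a stated time of 72 h (on this read-out higher numbers stand for weaker inhibition and lower numbers for stronger inhibition), compound 1 `Cc1cccc2c1cnn2-c1ccc(NC(=O)Nc2ccc(Cl)c(C(F)(F)F)c2)cc1` gives 5500 nM. Among the measured compounds shown here, of the two numbers measured so far, compound 1 holds the highest; its nearest neighbour is compound 2 `CNc1cccc2c1cnn2-c1ccc(NC(=O)Nc2ccc(Cl)c(C(F)(F)F)c2)cc1`, which in this assay gives 4900 nM, and the step of a 1.1-fold lower number from compound 1 to compound 2 (0.05 log units; within the scatter) lies within the scatter. Compound 3 `O=C(Nc1ccc(-n2ncc3cccnc32)cc1)Nc1ccc(Cl)c(C(F)(F)F)c1` is still unmeasured. It differs from compound 1 by a group of 9 heavy atoms (6 carbon, 3 nitrogen; one five-membered aromatic ring with 2 hetero atoms, one six-membered aromatic ring with 1 hetero atom) in place of a group of 10 heavy atoms (8 carbon, 2 nitrogen; one five-membered aromatic ring with 2 hetero atoms, one six-membered aromatic ring of carbon only), on an aromatic carbon, that is, a six-membered aromatic ring with 1 hetero atom in place of a six-membered aromatic ring of carbon only, on an aromatic carbon. For the measured compounds named here, no measured step touches this part of the shared core; the single known step, a 1.1-fold lower number from compound 1 to compound 2 (0.05 log units; within the scatter), changed a different place and stayed within the scatter. A step of no size beyond the scatter is therefore expected in this assay. Compound 3 is expected to give about 5500 nM, with a range from 2000 nM to 15000 nM. The expected step is no change at the digits printed from compound 1 to compound 3 (within the scatter).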

Compound 3, half-maximal inhibitory concentration: > 32000 nM
Compound 3: no number, only a limit; the forecaster's own chance of this, stated with the estimate: 5%; middle value at least 5.8-fold (0.76 log units) from the limit.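

Unlike the one earlier step at the shared core, a 1.1-fold lower number from compound 1 to compound 2 (0.05 log units; within the scatter), the change of the whole 4-methyl-1H-indazol-1-yl group shows that this place on the six-membered aromatic ring of carbon only can move the read-out in this assay, with an at least 5.8-fold higher number from compound 1 to compound 3 (0.76 log units; beyond the scatter). The entering group has a six-membered aromatic ring with 1 hetero atom and also carries no methyl, so this one step joins two differences. The result for compound 3 is a limit of the assay, not a number: the limit of > 32000 nM in this assay, at which 1 of the 3 values shown sits.

The compounds shown leave open which of those two differences carries the step, and how far it reaches beyond the limit. They also leave open how a methoxy group, an amine or a carboxylic acid on the entering ring would read.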